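The compounds below may be only part of what the source reports. "The series", "measured", "known", "first", "only" and "open" are said of these compounds alone.

Measured in an assay on HEK293 cells for displacement of a labelled ligand from D(4) dopamine receptor (Homo sapiens), read by scintillation counting, with a stated time of 1 h; on this read-out lower numbers stand for stronger inhibition and higher numbers for weaker inhibition:
- compound 1 `Clc1cccc(N2CCN(CCCCn3cc(-c4ccc(-c5ccccc5)cc4)nn3)CC2)c1Cl`: > 10000 nM, a limit of the assay
- compound 2 `COc1ccccc1N1CCN(CC(O)CCn2cc(-c3ccc4ncccc4c3)nn2)CC1`: > 3000 nM, a limit of the assay
- compound 3 `COc1ccccc1N1CCN(CCCCn2cc(-c3ccc4[nH]ccc4c3)nn2)CC1`: 222 nM

Compound 2 stands at a limit only, (the limit of > 3000 nM in this assay, at which 1 of the 3 values shown sits), so no number is known for it; compound 1 likewise sits at a limit, (the limit of > 10000 nM in this assay, at which 1 of the 3 values shown sits). Compound 3 alone has a measured value in this assay, 222 nM.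

Compound 4 `COc1ccccc1N1CCN(CC(O)CCn2cc(-c3ccc4ccccc4c3)nn2)CC1` differs from compound 2 in one place: naphthalen-2-yl in place of quinolin-6-yl on an aromatic carbon. For the measured compounds named here, no measured step in this assay is known that would size this change, and compound 2 itself is a limit, so the step is expected to be modest and toward stronger binding, an at least 2.0-fold lower number from compound 2 to compound 4 (0.30 log units; that floor lies within the scatter), with wide uncertainty. Compound 4 is estimated at 1500 nM, in the range 300 nM to 8000 nM.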

Compound 4, inhibition constant: > 2000 nM
Compound 4: no number, only a limit (the forecaster's own chance of this, stated with the estimate: 35%); middle value at least 1.3-fold (0.12 log units) from the limit.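

Compound 2 and compound 4 both stand only at limits; the step between them cannot be read. On these data alone, whether naphthalen-2-yl in place of quinolin-6-yl on this scaffold shifts the read-out at all, and in which direction, remains open.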